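This account rests on a few compounds, and the source may have more. Where it says the series, first, only, none or still open, it means among the compounds named here.

Compound 1, with the structure `NS(=O)(=O)c1cccc(/N=C2\NC(=O)/C(=C3/C(=O)Nc4ccccc43)S2)c1`, is one of three compounds that share a core and have been tested in a functional assay on Caco-2 cells (Homo sapiens) for antiproliferative activity, read by MTT assay; a higher number here means a weaker inhibitor, a lower number a stronger inhibitor. In this assay compound 1 gives 12100 nM, the lowest of the three numbers. Among the compounds with values here, compound 2, `CN1C(=O)/C(=C2\S/C(=N/c3ccc(S(N)(=O)=O)cc3)NC2=O)c2cc(Br)ccc21`, gives 13200 nM, a number that sits within the scatter of the one for compound 1, so no order between the two can be claimed. Compound 3, `NS(=O)(=O)c1ccc(/N=C2\NC(=O)/C(=C3/C(=O)Nc4ccc(F)cc43)S2)cc1`, gives 59900 nM, a higher number than compound 1 by a margin that lies beyond the scatter.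

The step under consideration leads from compound 1 to compound 4, whose structure is `COc1ccc2c(c1)/C(=C1/S/C(=N/c3cccc(S(N)(=O)=O)c3)NC1=O)C(=O)N2`. The change is methoxy in place of hydrogen on an aromatic carbon: a methoxy, with one hydrogen-bond acceptor and no donor, takes the place of a hydrogen on an aromatic carbon of a six-membered aromatic ring of carbon only, part of a fused or bridged system of two rings.

Within the data shown here, no pair of measured compounds differs in only one place, so no single-point step is available as a guide. The account expects a step from compound 1 to compound 4 of a 1.2-fold higher number from compound 1 to compound 4 (0.09 log units; within the scatter) in this assay, that is, none beyond the scatter. For compound 4 the estimated value in this assay is 15000 nM, with a range from 6000 nM to 40000 nM.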

Compound 4, half-maximal inhibitory concentration: 8390 nM
The estimate for compound 4 lay 1.8-fold (0.25 log units) above the measured number; measured number inside the range.
By their numbers in this assay, from the lowest: compounds 4, 1 and 2 (each within the scatter of the next); then compound 3.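

In this assay, putting a methoxy in place of hydrogen on this aromatic carbon, meta to a fused ring and para to a fused ring, gives a 1.4-fold lower number from compound 1 to compound 4 (0.16 log units; within the scatter) and so no change that can be told from the scatter. This is the first step among the compounds shown that differs in one place only, and it shows that this position of the shared core accepts a methoxy, with its 2 heavy atoms and its hydrogen-bond acceptor, without a readable gain or loss in antiproliferative activity. No measurement is at hand that bears on how this step comes to be so small.

On these data alone, whether a longer chain on the same oxygen, such as an ethoxy or a benzyloxy, or a group of another kind at this carbon, such as an amine or a carboxylic acid, would move the number beyond the scatter remains open. Also open, as far as these compounds go, is whether a methoxy would give a similar step on a compound carrying the other features of compound 2 or compound 3, since neither has a partner here that differs from it in one place.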